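Methoxy in place of hydrogen: from compound 3 to compound 4

The source may report more compounds than this note shows. Statements on the series, on what has been measured and on what is new or still open speak of the compounds shown alone.

Compound 1, `N#C/C(=C\c1ccc[nH]1)C(=O)NCc1ccc(Cl)c(Cl)c1`, 43000 nM
Compound 2, `COc1ccc(CNC(=O)/C(C#N)=C/c2ccoc2)cc1`, 7000 nM
Compound 3, `N#C/C(=C\c1ccccc1)C(=O)NCc1ccc(Cl)c(Cl)c1`, 32000 nM

Of the compounds shown here, three have been measured in a functional assay on BE(2)-C cells (Homo sapiens) for inhibition, read by MTT assay, with a stated time of 72 h; a lower number here means a stronger inhibitor of growth, a higher number a weaker inhibitor of growth. Compound 1 gives 43000 nM, compound 2 gives 7000 nM, and compound 3 gives 32000 nM. Compound 3 stands second highest of the three numbers; its nearest neighbour is compound 1, separated by a step within the scatter, a 1.3-fold lower number from compound 1 to compound 3 (0.13 log units; within the scatter), while compound 2 lies furthest away with a lower number beyond the scatter.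

Compound 4 `COc1ccc(/C=C(\C#N)C(=O)NCc2ccc(Cl)c(Cl)c2)cc1` differs from compound 3 in one place: methoxy in place of hydrogen on an aromatic carbon. For the measured compounds named here, no measured step exchanges hydrogen for methoxy on an aromatic carbon. Going by the values given here, compound 2 also carries a methoxy, but its structure differs from compound 3 in more than one place, so the two values of compound 2 and compound 3 show only that the pair lies beyond the scatter. Among the compounds with values here, the single measured step, a 1.3-fold lower number from compound 1 to compound 3 (0.13 log units; within the scatter), exchanges the aryl group and is small. The step expected in this assay from compound 3 to compound 4 is therefore a 1.3-fold lower number from compound 3 to compound 4 (0.11 log units; within the scatter), none beyond the scatter. Compound 4 is estimated at 25000 nM, within a range of 8000 nM to 80000 nM.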

Compound 4, concentration for 50% growth inhibition: 93000 nM
Compound 4: middle estimate off by 3.7-fold (0.57 log units), on the low side; the whole stated range lies below it.
By their numbers in this assay, from the lowest: compound 2; then compounds 3 and 1 (each within the scatter of the next); then compound 4.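

In this assay, methoxy on an aromatic carbon of the phenyl group, para to a large group, gives a 2.9-fold higher number from compound 3 to compound 4 (0.46 log units; beyond the scatter), so this position responds to substitution and this change weakens growth inhibition. The earlier exchange of aryl groups had stayed within the scatter, whereas 4-methoxyphenyl in place of 1H-pyrrol-2-yl gives a 2.2-fold higher number from compound 1 to compound 4 (0.34 log units; beyond the scatter), so the group on this chain carbon can shift the number once it carries methoxy. Nothing measured here accounts for this change.

The compounds shown leave open whether the shift is specific to methoxy or would also follow from hydroxy, an amine or a fluorine atom at this place. They also leave open whether the same exchange of hydrogen for methoxy would give a step of similar size with another group on the amide nitrogen.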